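Aromatic chloro on the core of compound 2: working notes

The source may hold more compounds than are shown below. What is called first, only, known or untested is meant among the compounds shown, and "the series" means these compounds.

For the measured compounds named here, in a functional assay on cells (Melanoma cell, Homo sapiens) for cytotoxicity, with a stated time of 48 h (on this read-out higher numbers stand for weaker inhibition of growth and lower numbers for stronger inhibition of growth), compound 2 `O=C1Nc2ccccc2/C1=C\c1c(Cl)n(CCCc2ccccc2)c2ccccc12` gives 67600 nM, the highest of the three numbers measured so far. Compound 1 `O=C1Nc2ccccc2/C1=C\c1c(Cl)n(Cc2ccccc2)c2ccccc12` gives 32400 nM and compound 3 `COc1cc2c(c(OC)c1OC)/C(=C\c1c(Cl)[nH]c3ccccc13)C(=O)N2` gives 6610 nM. Going by the values given here, the only single-change step in the set, a 2.1-fold higher number from compound 1 to compound 2 (0.32 log units; beyond the scatter), concerns the chain on the aromatic nitrogen, not a ring carbon, so it does not speak to the change at hand. Compound 4 `O=C1Nc2ccc(Cl)cc2/C1=C\c1c(Cl)n(CCCc2ccccc2)c2ccccc12` differs from compound 2 by chloro in place of hydrogen on an aromatic carbon, on the six-membered aromatic ring of carbon only in the core of compound 2, meta to a fused ring and para to a fused ring. Among the compounds with values here, no measured pair isolates a substituent at that place; compound 3 differs from compound 2 in several places at once, and its value shows only that the series spans a wide range. Expect therefore no step beyond the scatter in this assay from compound 2 to compound 4, with wide uncertainty. Compound 4 is estimated at 60000 nM, range 20000 nM to 150000 nM. The implied step a 1.1-fold lower number from compound 2 to compound 4 (0.05 log units; within the scatter) is expected to be small.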

Compound 4, concentration for total growth inhibition: 5750 nM
Beside the measured number, compound 4's estimate is 10-fold (1.02 log units) above it; measured number outside the range, below it.
By their numbers in this assay, from the lowest: compounds 4 and 3 (each within the scatter of the next); then compound 1; then compound 2.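

In this assay, chloro in place of hydrogen on an aromatic carbon, meta to a fused ring and para to a fused ring, gives a 12-fold lower number from compound 2 to compound 4 (1.07 log units; beyond the scatter) and so shows that this position of the core is not silent. For the compounds shown here, this is the first single-change step on a ring carbon of the core, it runs toward stronger inhibition of growth, and it is larger than the step on the chain at the aromatic nitrogen, a 2.1-fold higher number from compound 1 to compound 2 (0.32 log units; beyond the scatter); a single chlorine on the ring counts for more here than that change in the chain. Nothing on hand accounts for the size of the step.

As far as these compounds go, whether the gain is particular to chloro remains open, since no amine or carboxylic acid at this place can be compared. Also open, from the compounds shown here alone, is whether chloro at the same place would act alike on compound 1, with its shorter chain on the aromatic nitrogen.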